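The source may report more compounds than this note shows. Statements on the series, on what has been measured and on what is new or still open speak of the compounds shown alone.

Measured compounds and their values in a functional assay on Jurkat cells for inhibition of nuclear factor NF-kappa-B complex (Homo sapiens); on this read-out lower numbers stand for stronger inhibition and higher numbers for weaker inhibition:
compound 1, `CCOC(=O)c1cnc(C(F)(F)F)nc1NN1C(=O)C=C(C)C1=O`: 1000 nM
compound 2, `CCOC(=O)c1cnc(-c2cc(Cl)nc(Cl)c2)nc1NN1C(=O)C=C(C)C1=O`: 2000 nM
compound 3, `CCOC(=O)c1cnc(-c2cccc(OC)c2)nc1NN1C(=O)C=C(C)C1=O`: 5000 nM

Compound 3 gives the highest number of the three in this assay: the step of a 2.5-fold higher number from compound 2 to compound 3 (0.40 log units; beyond the scatter) and the step of a 5.0-fold higher number from compound 1 to compound 3 (0.70 log units; beyond the scatter) both lie beyond the scatter, so compound 3 is the weakest inhibitor of the set, with compound 2 nearest to it. Compound 4, `CCOC(=O)c1cnc(-c2ccsc2)nc1NN1C(=O)C=C(C)C1=O`, differs from compound 3 in one place: thiophen-3-yl in place of 3-methoxyphenyl on an aromatic carbon.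

The measured steps that bear on this change are those that alter the same position. The step of a 5.0-fold higher number from compound 1 to compound 3 (0.70 log units; beyond the scatter) and the step of a 2.5-fold higher number from compound 2 to compound 3 (0.40 log units; beyond the scatter) show that the group at this position shifts the number over a modest range, and that compound 3 carries the group that gives the highest number. Going by the values given here, replacing it by thiophen-3-yl is therefore expected to move compound 4 somewhat back toward the numbers of compound 1 and compound 2, though the data give no direct precedent for a five-membered ring here. Compound 4 is expected to give about 2500 nM in this assay, in a range from 1000 nM to 6000 nM, which means an expected step of a 2.0-fold lower number from compound 3 to compound 4 (0.30 log units; within the scatter).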

Compound 4, half-maximal inhibitory concentration: 100 nM
The estimate for compound 4 lay 25-fold (1.40 log units) above the measured number, and the stated range ends above it.
By their numbers in this assay, from the lowest: compound 4; then compounds 1 and 2 (each within the scatter of the next); then compound 3.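

In this assay thiophen-3-yl, at the place between two ring nitrogen atoms, gives the strongest inhibitor of the four compounds, with a 50-fold lower number from compound 3 to compound 4 (1.70 log units; beyond the scatter) and a 20-fold lower number from compound 2 to compound 4 (1.30 log units; beyond the scatter) and a 10-fold lower number from compound 1 to compound 4 (1.00 log units; beyond the scatter) at this position. The earlier compounds shown here spanned only a modest range here, so the group at this position can move the number much further than they showed, and a five-membered aromatic ring with 1 hetero atom gives a lower number than trifluoromethyl or either six-membered aromatic ring. Nothing measured here accounts for this result.

How phenyl, thiophen-2-yl or furan-3-yl would compare at this position stays open, so the compounds shown cannot separate the part played by the sulfur atom from that of the ring size. From the compounds shown here alone, whether the same gain would hold with a carboxylic acid in place of the ethoxycarbonyl group is also open.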